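A few compounds are considered here, and "the series" means these few. Any claim that something is new, unique, unknown or untested is made for them only; others in the source may bear on it.

Compound 1 `CCCC[N+](C)(C)CCCC(=O)[O-]` and compound 2 `CCC[N+](C)(C)CCCC(=O)[O-]` share a quaternary ammonium core carrying a carboxylate-terminated chain, and they differ by methyl in place of hydrogen on a saturated chain carbon, three bonds along the chain from an amine nitrogen. In an assay for inhibition of gamma-butyrobetaine dioxygenase (Homo sapiens), read by HPLC, with stated times of 15 min and 30 min (a higher number here means a weaker inhibitor, a lower number a stronger inhibitor), compound 1 gives > 1000000 nM, a limit of the assay rather than a number. In this assay compound 2 likewise gives > 1000000 nM, again a limit and not a number. The step that the two limits leave unreadable from compound 2 to compound 1 therefore cannot be read, because both values sit at the limit of > 1000000 nM in this assay, at which 2 of the 3 values shown sit. Compound 3 `CN(CCC(=O)[O-])[N+](C)(C)C` has a different core, and the difference between the two cores is not broken down here. In this assay, within the data shown here, compound 3 gives 90 nM, the only number among the three.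

Compound 4 `CC[N+](C)(C)N(C)CCC(=O)[O-]` has not yet been measured. It differs from compound 3 by methyl in place of hydrogen on a saturated chain carbon bound to an amine nitrogen. This is the same kind of change as that from compound 2 to compound 1, but the place is not the same: there the methyl enters three bonds along the chain from an amine nitrogen, here on a saturated chain carbon bound to an amine nitrogen. Since the earlier step is unreadable, the expectation for compound 4 rests mainly on the value of compound 3, 90 nM, and the expected step is a 6.7-fold higher number from compound 3 to compound 4 (0.82 log units; beyond the scatter). Compound 4 is estimated at 600 nM, between 100 nM and 6000 nM.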

Compound 4, half-maximal inhibitory concentration: 7200 nM
Estimate against measurement, compound 4: 12-fold (1.08 log units) below; measured number outside the range, above it.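

In this assay, methyl in place of hydrogen on a saturated chain carbon bound to an amine nitrogen gives an 80-fold higher number from compound 3 to compound 4 (1.90 log units; beyond the scatter), so on the core of compound 3 this single added carbon carries a large penalty. The same kind of change on the other core, with the methyl three bonds along the chain from an amine nitrogen, cannot be read, because compound 1 and compound 2 both stand at a limit of the assay and not at a number: the limit of > 1000000 nM in this assay, at which 2 of the 4 values shown sit. The series therefore shows the size of the change on one core only and does not show whether it carries over to the other, where the place of the change also differs.

Going by these compounds, it remains open whether a longer chain, such as propyl in place of the ethyl of compound 4, would move the number further in the same direction. Also open, on these data alone, is how either core would respond if an ester or a primary amide stood in place of the carboxylate.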